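The source may hold more compounds than are shown below. What is called first, only, known or untested is meant among the compounds shown, and "the series" means these compounds.

Of the compounds shown here, two carry numbers so far. Compound 1 `CC(C)(C)c1csc(N)c1C(=O)c1ccc(Cl)cc1` gives 1% in an assay on CHO cells for displacement of a labelled ligand from adenosine receptor A3 (Homo sapiens), read by scintillation counting, tested at 10 uM (on this read-out lower numbers stand for less inhibition and higher numbers for more inhibition at the one concentration tested (going by the name of the read-out)), and compound 2 `CC(C)(C)Cc1csc(N)c1C(=O)c1ccc(Cl)cc1` gives 5% in this assay. For the measured compounds named here, the single step joining them, a number 4 percentage points higher from compound 1 to compound 2 (within the scatter), lies within the scatter. Compound 2 thus holds the higher of the two numbers shown, with compound 1 as its only neighbour, yet the two readings cannot be told apart.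

Compound 3 `CC(C)(C)Cc1c(-c2cccnc2)sc(N)c1C(=O)c1ccc(Cl)cc1` follows from compound 2 by pyridin-3-yl in place of hydrogen on an aromatic carbon. Going by the values given here, no measured step bears on this change: the one step in hand exchanges one alkyl group for another on a ring carbon and says nothing about adding an aromatic ring. The direction of the change is therefore open, and the expectation must be wide. It rests on compound 2 alone, whose reading of 5% in this assay sits near the bottom of the scale. Compound 3 is estimated at 15%, with a range from 0% to 45%. That estimate corresponds to an expected step of a number 10 percentage points higher from compound 2 to compound 3 (within the scatter), which does not clearly rise beyond the scatter.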

Compound 3, a percentage reported as inhibition, at one concentration (the size of the read-out at that concentration, not a potency): 1%
Estimate against measurement, compound 3: 14 percentage points above; measured number inside the range.
By their numbers in this assay, from the lowest: compounds 1, 3 and 2 (each within the scatter of the next).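

Placed on the aromatic carbon next to the ring sulfur, pyridin-3-yl in place of hydrogen gives, in this assay, a number 4 percentage points lower from compound 2 to compound 3 (within the scatter). For the compounds shown here, this is the first look at this ring position, and it shows that an added six-membered aromatic ring with a ring nitrogen leaves the reading indistinguishable from that of compound 2, just as the exchange of alkyl groups on the other ring carbon did in a number 4 percentage points higher from compound 1 to compound 2 (within the scatter). Nothing measured here gives a reason for this outcome.

On these data alone, neither step separates any of the compounds, so it remains open whether any substituent on the shared core can bring a reading clearly beyond the scatter in this assay. A phenyl ring, a morpholine or a carboxylic acid at this position could test that, as could a longer chain in place of neopentyl or an acetamide in place of the amino group.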